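The source may report more compounds than this note shows. Statements on the series, on what has been measured and on what is new or still open speak of the compounds shown alone.

Measured in a functional assay on SMMC-7721 cells (Homo sapiens) for inhibition, read by CCK-8 assay, with a stated time of 72 h, tested at 2 uM; a lower number here means less inhibition of growth, a higher number more inhibition of growth at the concentration tested:
- compound 1 `COc1ccc(SCc2ccc(C(=O)Nc3ccccc3N)cc2)cc1`: 33.1%
- compound 2 `Nc1ccccc1NC(=O)c1ccc(CSc2ccc(Br)cc2)cc1`: 10%

Compound 1, at 33.1%, is the higher of the two values. Compound 3 `COc1ccc(SCc2ccc(C(=O)Nc3ccccc3N)cc2)cc1OC` differs from it by methoxy in place of hydrogen on an aromatic carbon. Within the data shown here, the only measured step, a number 23.1 percentage points lower from compound 1 to compound 2 (beyond the scatter), exchanges a methoxy group for bromo, so it bears on this change only indirectly. Among the measured compounds shown here, no measured step adds a group in place of hydrogen, and compound 3 retains the methoxy group that compound 2 lacks. A small loss is therefore expected, with the expected a number 5.1 percentage points lower from compound 1 to compound 3 (within the scatter) not clearly exceeding the scatter. For compound 3, the estimated value is 28%, within an expected range of 12% to 45%.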

Compound 3, percent growth inhibition at one concentration: 20.2%
For compound 3 the middle estimate is 7.8 percentage points above the measured one; low and high end bracket the measured number.
By their numbers in this assay, from the lowest: compound 2; then compound 3; then compound 1.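

The step of a number 12.9 percentage points lower from compound 1 to compound 3 (beyond the scatter) in this assay comes with methoxy in place of hydrogen on an aromatic carbon, ortho to a methoxy group. Unlike the earlier exchange of methoxy for bromo, this step adds a group at an open ring position, and here the added methoxy group costs growth inhibition beyond the scatter. Nothing available explains this loss.

Only one group is shown at this position. On these data alone, whether a hydroxyl, a fluoro or an amine there would also lower the number remains open.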